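Triazole aryl swap in a series stuck at the limit

The source may report more compounds than this note shows. Statements on the series, on what has been measured and on what is new or still open speak of the compounds shown alone.

Compound 3 `Cc1ccc(C)c(-n2nncc2CN2C(=O)C3(C(C#N)=C(N)Oc4c(N)cc5nc6ccccc6nc5c43)c3ccccc32)c1` reaches only a limit in an ADME assay on HUVEC cells (Homo sapiens) for antiproliferative activity, read by MTT assay, with a stated time of 48 h; on this read-out lower numbers stand for stronger inhibition and higher numbers for weaker inhibition: there compound 3 gives > 50000 nM. Its two relatives also stop at limits. In this assay compound 1 `N#CC1=C(N)Oc2c(N)cc3nc4ccccc4nc3c2C12C(=O)N(Cc1cnnn1-c1cccc(Br)c1)c1ccccc12` gives > 50000 nM. In this assay compound 2 `COc1ccccc1-n1nncc1CN1C(=O)C2(C(C#N)=C(N)Oc3c(N)cc4nc5ccccc5nc4c32)c2ccccc21` gives > 50000 nM. The steps a step that the two limits leave unreadable from compound 1 to compound 2, a step that the two limits leave unreadable from compound 1 to compound 3 and a step that the two limits leave unreadable from compound 2 to compound 3 therefore cannot be sized because all three values sit at the limit of > 50000 nM in this assay, at which 3 of the 3 values shown sit. Compound 4 `Cc1ccc(-n2nncc2CN2C(=O)C3(C(C#N)=C(N)Oc4c(N)cc5nc6ccccc6nc5c43)c3ccccc32)cc1Cl` carries 3-chloro-4-methylphenyl in place of 2,5-dimethylphenyl on an aromatic nitrogen. Among the measured compounds shown here, none of the measured aryl swaps gives a readable size or direction, so no shift beyond the scatter can be read from them for this change. Compound 4 is thus expected to remain at the limit, with an estimated step that the limit leaves unreadable from compound 3 to compound 4. The estimate for compound 4 is 80000 nM, spanning 30000 nM to 300000 nM.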

Compound 4, half-maximal inhibitory concentration: > 50000 nM
Compound 4 was reported as a limit; the forecaster's own chance of this, stated with the estimate: 85%; the middle value does not contradict the limit.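

Compound 4 also stops at a limit in this assay, so no step among compound 1, compound 2, compound 3 and compound 4 can be read: the limit of > 50000 nM in this assay, at which 4 of the 4 values shown sit.

The compounds shown leave open whether any aryl group on this aromatic nitrogen shifts the read-out in this assay at all.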